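Moving the Hydroxyl Around the Phenyl Ring

The source may hold more compounds than are shown below. What is called first, only, known or untested is meant among the compounds shown, and "the series" means these compounds.

Three compounds on a shared core were tested in a functional assay on DU-145 cells (Homo sapiens) for inhibition; on this read-out lower numbers stand for stronger inhibition and higher numbers for weaker inhibition. Compound 1 `Oc1ccc(-c2cc(-c3ccccc3C(F)(F)F)cc(-c3ccccc3O)n2)cc1` gives 6690 nM and compound 2 `Oc1ccccc1-c1cc(-c2ccccc2OC(F)(F)F)cc(-c2ccccc2O)n1` gives 5850 nM. Compound 3 `Oc1cccc(-c2cc(-c3ccccc3OC(F)(F)F)cc(-c3ccccc3O)n2)c1` reaches only the limit of the assay, > 50000 nM. For the measured compounds named here, the step of an at least 8.5-fold higher number from compound 2 to compound 3 (0.93 log units; beyond the scatter) is the one measured change of this kind, and compound 3 sits at the limit of > 50000 nM in this assay, at which 1 of the 3 values shown sits, so its number is not known exactly. Compound 4 `Oc1ccc(-c2cc(-c3ccccc3OC(F)(F)F)cc(-c3ccccc3O)n2)cc1` differs from compound 3 by 4-hydroxyphenyl in place of 3-hydroxyphenyl on an aromatic carbon. Compound 1 also carries a 4-hydroxyphenyl and gives 6690 nM, so a return toward the range of compound 1 and compound 2 is expected, a step of an at least 7.1-fold lower number from compound 3 to compound 4 (0.85 log units; beyond the scatter). Compound 4 is therefore estimated at 7000 nM, between 3000 nM and 25000 nM.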

Compound 4, half-maximal inhibitory concentration: 4190 nM
Compound 4: the middle estimate sits 1.7-fold (0.22 log units) above what was measured; the range from low to high includes it.
By their numbers in this assay, from the lowest: compounds 4, 2 and 1 (each within the scatter of the next). At a limit, above all of these: compound 3.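

In this assay, this position proves sensitive to where the hydroxyl sits, since 4-hydroxyphenyl restores what 3-hydroxyphenyl loses (an at least 11-fold lower number from compound 3 to compound 4 (1.07 log units; beyond the scatter)). For compound 3, that step rests on a limit and not on a number: the limit of > 50000 nM in this assay, at which 1 of the 4 values shown sits. The 4-hydroxyphenyl and 2-hydroxyphenyl groups are not separated here (a 1.4-fold lower number from compound 2 to compound 4 (0.14 log units; within the scatter)), and with 4-hydroxyphenyl in place, neither are trifluoromethoxy and trifluoromethyl (a 1.6-fold lower number from compound 1 to compound 4 (0.20 log units; within the scatter)).

Whether this position needs a hydroxyl at all remains open, as no compound shown carries a methoxy, an amine or a carboxylic acid there. From the compounds shown here alone, how weak compound 3 really is also remains unknown.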